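The compounds below may be only part of what the source reports. "The series", "measured", "known", "first", "only" and "open" are said of these compounds alone.

Growth inhibition of the series in a functional assay on PANC-1 cells (Homo sapiens) for inhibition, read by MTT assay, with a stated time of 72 h; on this read-out higher numbers stand for weaker inhibition of growth and lower numbers for stronger inhibition of growth:

compound 1, `CC(C)(C)c1ccc(CNCCCNS(=O)(=O)c2cc(C(F)(F)F)cc(C(F)(F)F)c2)cc1`: 2500 nM
compound 2, `O=S(=O)(NCCCCNCc1ccc(Br)cc1)c1cc(C(F)(F)F)cc(C(F)(F)F)c1`: 2200 nM
compound 3, `O=S(=O)(NCCCNCC1COc2ccccc2O1)c1cc(C(F)(F)F)cc(C(F)(F)F)c1`: 3400 nM

Compound 2 gives the smallest number of the three, yet neither compound 1 nor compound 3 is separated from it by more than the scatter, so the three stand together as one level of activity.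

Compound 4 `O=S(=O)(NCCCNCc1cccc(Cl)c1)c1cc(C(F)(F)F)cc(C(F)(F)F)c1` differs from compound 2 by (3-chlorobenzyl)amino in place of ((4-bromobenzyl)amino)methyl on a saturated chain carbon, three bonds along the chain from a sulfonamide nitrogen. Within the data shown here, the only measured step that bears on this, a 1.4-fold higher number from compound 1 to compound 3 (0.13 log units; within the scatter), exchanges the aryl group on the saturated carbon bound to the amine nitrogen and stays within the scatter. Among the measured compounds shown here, no measured step shortens the chain by one carbon, and none moves or exchanges the halogen on the benzyl ring, so those parts of the change have no direct precedent here. On the evidence at hand the expected step of a 1.3-fold higher number from compound 2 to compound 4 (0.10 log units; within the scatter) in this assay is none beyond the scatter. Compound 4 is therefore estimated at 2800 nM, with a range from 1400 nM to 5600 nM.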

Compound 4, concentration for 50% growth inhibition: 12000 nM
Compound 4: middle estimate off by 4.3-fold (0.63 log units), on the low side, and the stated range ends below it.
By their numbers in this assay, from the lowest: compounds 2, 1 and 3 (each within the scatter of the next); then compound 4.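

In this assay the aryl group on the saturated chain carbon bound to an amine nitrogen is not neutral after all: 3-chlorophenyl gives steps beyond the scatter against both earlier groups (a 4.8-fold higher number from compound 1 to compound 4 (0.68 log units; beyond the scatter)) (a 3.5-fold higher number from compound 3 to compound 4 (0.55 log units; beyond the scatter)), though the exchange between those two groups stayed within it. Since these two steps leave the chain as it is, the rise seen in the wider change (a 5.5-fold higher number from compound 2 to compound 4 (0.74 log units; beyond the scatter)) does not need a change of chain length to appear. Nothing measured here accounts for the rise.

Open, as far as these compounds go, is whether the rise follows the chlorine itself or its place on the ring, which a 4-chlorobenzyl group on the chain of compound 4 would separate. Also open is what chain length alone contributes, since no pair shown differs only there.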